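Adding a Second Trifluoromethyl to a Diaryl Urea

A few compounds are considered here, and "the series" means these few. Any claim that something is new, unique, unknown or untested is made for them only; others in the source may bear on it.

Measured so far in a functional assay on Malme-3M cells (Homo sapiens) for inhibition, read by sulforhodamine B assay, with a stated time of 48 h, tested at 100 uM; on this read-out lower numbers stand for a stronger effect and higher numbers for a weaker effect at the one concentration tested:
Compound 1 `COc1cc(Cl)cc(-c2nn(-c3cccc(NC(=O)Nc4cccc(C(F)(F)F)c4)c3)cc2-c2ccncc2)c1` gives -26%
Compound 2 `COc1cc(Cl)cc(-c2nn(-c3cccc(NC(=O)c4cccc(C(F)(F)F)c4)c3)cc2-c2ccncc2)c1` gives 55%

Compound 1 stands lowest of the two numbers, meaning it shows the stronger effect in this assay. Within the data shown here, its only neighbour is compound 2, and the step of a number 81 percentage points higher from compound 1 to compound 2 (beyond the scatter) is large. That step, however, concerns the carbonyl carbon, not the aromatic ring that is altered here.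

Compound 3 `COc1cc(Cl)cc(-c2nn(-c3cccc(NC(=O)Nc4cc(C(F)(F)F)cc(C(F)(F)F)c4)c3)cc2-c2ccncc2)c1` differs from compound 1 by trifluoromethyl in place of hydrogen on an aromatic carbon. Among the measured compounds shown here, no measured pair tests a change of this kind, so the size of the expected step rests on compound 1 alone. Since the added group repeats one already present on the same ring, the expectation is a small step, if any, and within the scatter: a number 4 percentage points lower from compound 1 to compound 3 (within the scatter). Compound 3 is therefore estimated at -30%, in the range -65% to 10%.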

Compound 3, a percentage reported as activity, at one concentration (the size of the read-out at that concentration, not a potency): -39%
Compound 3: the middle estimate sits 9 percentage points above what was measured; measured number inside the range.
By their numbers in this assay, from the lowest: compound 3; then compound 1; then compound 2.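

In this assay the ring carrying the trifluoromethyl group accepts a second one at this aromatic carbon, and the change gives a number 13 percentage points lower from compound 1 to compound 3 (beyond the scatter) on going from hydrogen to trifluoromethyl. Among these compounds, this is the first look at a change on this ring itself, since the earlier pair altered only the link at the carbonyl, where the result was a number 81 percentage points higher from compound 1 to compound 2 (beyond the scatter) and the effect weakened, whereas here it grows by a modest step. No measurement at hand explains why the number falls.

Going by these compounds, whether the gain belongs to trifluoromethyl in particular stays open, as a nitrile or an amine on the same carbon would be needed to tell. Also open, on these data alone, is whether the same addition would lower the number of the amide compound 2.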